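The source may report more compounds than this note shows. Statements on the series, on what has been measured and on what is new or still open speak of the compounds shown alone.

Measured compounds: compound 1 `CC(C)(C)n1ncc(OCc2nnc(-c3ccc(Cl)cc3Cl)s2)c(Cl)c1=O` with 62200 nM and compound 2 `CC(C)(C)n1ncc(OCc2nnc(-c3cccc(F)c3)o2)c(Cl)c1=O` with 7100 nM, both in a functional assay on the whole organism for inhibition, with Mythimna separata as the target, with a stated time of 5 days; on this read-out lower numbers stand for an effect already at smaller amounts and higher numbers for an effect only at larger amounts of compound.

On this assay compound 1 stands at the highest number of the two; the only other entry, compound 2, shows a markedly lower number, beyond the scatter, but the two structures differ in more than one place, so no single step can be read from them. Compound 3 `CC(C)(C)n1ncc(OCc2nnc(-c3ccccc3)s2)c(Cl)c1=O` is not yet measured. It differs from compound 1 by phenyl in place of 2,4-dichlorophenyl on an aromatic carbon. Going by the values given here, with no directly comparable step available, the expectation for compound 3 is a moderate move toward a lower number, a 2.1-fold lower number from compound 1 to compound 3 (0.32 log units; beyond the scatter), beyond the scatter but not large. Compound 3 is accordingly estimated at 30000 nM, within a range from 8000 nM to 120000 nM.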

Compound 3, half-maximal effective concentration: 200000 nM
Compound 3: middle estimate off by 6.7-fold (0.82 log units), on the low side, outside the stated range (above it).
By their numbers in this assay, from the lowest: compound 2; then compound 1; then compound 3.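

The first single-place comparison shows that this position, the aromatic carbon bearing the aryl group, responds to its substituents: in this assay, phenyl in place of 2,4-dichlorophenyl gives a 3.2-fold higher number from compound 1 to compound 3 (0.51 log units; beyond the scatter), a modest step beyond the scatter. Keeping the two chlorines is therefore linked to effect at smaller amounts on this core. No available evidence bears on the reason for this step.

Going by these compounds, it remains open whether a single chlorine, as in 4-chlorophenyl, would be enough, or how a methoxy or trifluoromethyl group would compare. On these data alone, whether the same change would hold on the core of compound 2 is also open.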